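Swapping hydroxy for methylamino on a potent antiproliferative compound

The source may report more compounds than this note shows. Statements on the series, on what has been measured and on what is new or still open speak of the compounds shown alone.

Measured in a functional assay on A2780 cells (Homo sapiens) for antiproliferative activity, read by MTT assay, with a stated time of 48 h; a higher number here means a weaker inhibitor, a lower number a stronger inhibitor:
Compound 1 `CCNCC(=O)Nc1cc(OC)ccc1C(=O)c1ccc(OC)c2c1OC(C)(C)C=C2`: 1980 nM
Compound 2 `C=C(c1ccc(OC)cc1NC(=O)CO)c1ccc(OC)c2c1OC(C)(C)C=C2`: 40 nM
Compound 3 `C=C(c1cc(OC)c(OC)c(OC)c1)c1ccc(OC)cc1NC(=O)CO`: 30 nM

Compound 2 lies within the scatter of compound 3 and far beyond it from compound 1, which has the higher number. Compound 4 `C=C(c1ccc(OC)cc1NC(=O)CNC)c1ccc(OC)c2c1OC(C)(C)C=C2` differs from compound 2 by one change, (methylamino in place of hydroxy on a saturated chain carbon bound to a carbonyl carbon), with methylamino in place of hydroxy on a saturated chain carbon bound to a carbonyl carbon. Within the data shown here, no measured pair isolates this change. Compound 1, at 1980 nM, also carries an amino group on that chain but differs elsewhere too, so it is only a weak hint. A moderate weakening is expected in this assay, an estimated step of a 3.0-fold higher number from compound 2 to compound 4 (0.48 log units; beyond the scatter). Compound 4 is estimated at 120 nM, with an expected range of 30 nM to 500 nM.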

Compound 4, half-maximal inhibitory concentration: 210 nM
The estimate for compound 4 lay 1.8-fold (0.24 log units) below the measured number; low and high end bracket the measured number.
By their numbers in this assay, from the lowest: compounds 3 and 2 (each within the scatter of the next); then compound 4; then compound 1.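

In this assay, among these compounds, methylamino in place of hydroxy on a saturated chain carbon bound to a carbonyl carbon gives a 5.3-fold higher number from compound 2 to compound 4 (0.72 log units; beyond the scatter), the first reading of this change on its own. The position is therefore sensitive to this swap, even though the two groups count the same hydrogen-bond donors and acceptors. Nothing available explains the loss.

As far as these compounds go, whether it follows from the nitrogen or the added carbon stays open; a primary amine or methoxy on that carbon would separate the two. From the compounds shown here alone, whether the step carries over to the core of compound 3 also remains open.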